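A Nitrogen-Bearing Ring Replaces an All-Carbon Group

This account rests on a few compounds, and the source may have more. Where it says the series, first, only, none or still open, it means among the compounds named here.

In a physicochemical assay for solubility, at pH 6.5 (a lower number here means a less soluble compound, a higher number a more soluble compound), compound 1 `O=C(Nc1ccc2ccccc2c1)NC1CCN(C/C2=C/CCCCCC2)CC1` gives 0.1 ug/mL. Compound 2 `CC1(C)[C@H]2CC=C(CN3CCC(NC(=O)Nc4cc(C(F)(F)F)cc(C(F)(F)F)c4)CC3)[C@@H]1C2` gives < 1 ug/mL, which is a limit of the assay and not a number. Its true position is therefore unknown, and these two results cannot rank it against compound 1.

Compound 3 `CC(C)(C)C(=O)N1CCC(CN2CCC(NC(=O)Nc3cc(C(F)(F)F)cc(C(F)(F)F)c3)CC2)CC1` differs from compound 2 in one place, on a saturated chain carbon bound to an amine nitrogen in a ring. There, 1-((tert-butyl)carbonyl)piperidin-4-yl takes the place of an all-carbon group: a group of 12 heavy atoms (10 carbon, 1 nitrogen, 1 oxygen; one six-membered non-aromatic ring with 1 hetero atom) in place of a group of 9 heavy atoms (9 carbon; one four-membered non-aromatic ring of carbon only, one six-membered non-aromatic ring of carbon only), on a saturated chain carbon bound to an amine nitrogen in a ring.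

For the measured compounds named here, no measured pair shows what such a swap does in this assay. Going by the values given here, the only firm number so far is low, with compound 1 at 0.1 ug/mL, so only a modest rise is expected. The estimated step of an at least 2.0-fold higher number from compound 2 to compound 3 (0.30 log units; that floor lies within the scatter) reflects that caution. For compound 3 the expected value is 2 ug/mL, within a range of 0.3 ug/mL to 10 ug/mL.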

Compound 3, solubility: 45 ug/mL
Beside the measured number, compound 3's estimate is 23-fold (1.35 log units) below it; the whole stated range lies below it.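

In this assay, the group on a saturated chain carbon bound to an amine nitrogen in a ring proves able to move the read-out well beyond the usual scatter: putting 1-((tert-butyl)carbonyl)piperidin-4-yl in place of the all-carbon group gives an at least 45-fold higher number from compound 2 to compound 3 (1.65 log units; beyond the scatter). For the compounds shown here, until this pair, no measured step showed what a change at this place could do. Compound 2 gives a limit and not a number, so this step is only a floor and its full size stays unknown: the limit of < 1 ug/mL in this assay, at which 1 of the 3 values shown sits.

The swap changes several things at once, bringing in a ring nitrogen, a carbonyl and a tert-butyl group, and the compounds shown cannot separate their shares in the rise. Going by these compounds, it remains open whether a smaller acetyl group on that ring nitrogen, or a free ring amine with no carbonyl, would give a similar rise.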